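Moving a Fluorine on an Anilino Ring: Expected Half-Life

This account rests on a few compounds, and the source may have more. Where it says the series, first, only, none or still open, it means among the compounds named here.

Of the compounds shown here, three have been measured in an ADME assay on microsomes from liver (Mus musculus) for metabolic stability, read by LC-MS, using NADPH; a higher number here means that the compound lasts longer, a lower number that the compound disappears faster. Compound 1 `Cc1cccnc1Nc1ncc(-c2ccccn2)o1` gives 0.0233 h. Compound 2 `O=C(O)c1cccc(-c2csc(-c3ccccc3F)n2)c1` gives 3.4 h. Compound 3 `O=C(O)c1cccc(-c2csc(Nc3ccccc3F)n2)c1` gives 0.532 h. Among these three numbers compound 3 holds the second highest: its nearest neighbour is compound 2, whose number is higher by a gap beyond the usual scatter, and compound 1 lies furthest away, lower by a gap that is also beyond the scatter.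

Compound 4 `O=C(O)c1cccc(-c2csc(Nc3ccc(F)cc3)n2)c1` has not yet been measured in this assay. It shares every atom with compound 3, joined differently: 4-fluorophenyl in place of 2-fluorophenyl on a nitrogen on an aromatic ring. Among the measured compounds shown here, no pair of measured compounds differs in exactly this way, so no measured step shows how such a change has played out before. An expectation must therefore rest on compound 3 alone, with its 0.532 h, and the cautious view is that a rearrangement this small should move the half-life only a little. The step from compound 3 to compound 4 is expected to be a 1.3-fold higher number from compound 3 to compound 4 (0.12 log units; within the scatter), a modest rise that may well stay inside the scatter. Compound 4 is accordingly estimated at 0.7 h, with a range from 0.25 h to 2 h.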

Compound 4, half-life: 0.635 h
Compound 4: middle estimate off by 1.1-fold (0.04 log units), on the high side, within the range that was stated.
By their numbers in this assay, from the lowest: compound 1; then compounds 3 and 4 (each within the scatter of the next); then compound 2.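

In this assay, among the compounds shown here, putting 4-fluorophenyl in place of 2-fluorophenyl on a nitrogen on an aromatic ring gives a 1.2-fold higher number from compound 3 to compound 4 (0.08 log units; within the scatter), the first measured step at this place. Since the step lies within the scatter, compounds 3 and 4 cannot be told apart, and in this one pair the choice between these two fluorophenyl groups leaves no readable mark on the half-life. No measurement here offers an explanation for this result.

This single pair shows only that these two arrangements of the same atoms give matching half-lives on this core, so it cannot say whether a different group on that nitrogen, such as a methoxyphenyl or a chlorophenyl, would shift the number beyond the scatter. It also leaves open whether the same swap would behave alike on another core, and how the half-life would respond if an amide stood in place of the carboxylic acid that compounds 3 and 4 share.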